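The source may hold more compounds than are shown below. What is called first, only, known or untested is meant among the compounds shown, and "the series" means these compounds.

Measured compounds:
- compound 1 `COc1ccc2c(=O)cc(Cc3ccncc3)oc2c1` — 3600 nM
- compound 2 `O=c1c(Cc2c[nH]cn2)coc2ccccc12` — 29.5 nM

Two compounds have been run in an assay on V79MZh cells for inhibition of cytochrome P450 11B1, mitochondrial (Homo sapiens), with a stated time of 6 h; on this read-out lower numbers stand for stronger inhibition and higher numbers for weaker inhibition. Compound 2 gives 29.5 nM, the lower of the two numbers. Compound 1, on a different core, gives 3600 nM; this gap lies well beyond the usual scatter, so compound 2 is clearly the stronger inhibitor of the pair.

Compound 3 `O=c1c(Cc2cccnc2)coc2ccccc12` keeps the core of compound 2 and differs from it in one place: pyridin-3-yl in place of 1H-imidazol-4-yl on a saturated chain carbon bound to an aromatic carbon. Within the data shown here, no directly comparable step between measured compounds exists for this change. Because compound 2 gives 29.5 nM and compound 1, a different core, sits far higher, the expectation is a weakening in this assay, with wide uncertainty. Compound 3 is therefore expected to give about 300 nM, within 50 nM to 2000 nM. The implied step is estimated as a 10-fold higher number from compound 2 to compound 3 (1.01 log units; beyond the scatter).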

Compound 3, half-maximal inhibitory concentration: > 10000 nM
Compound 3 gave a limit, no number; the forecaster's own chance of this, stated with the estimate: 5%; middle value at least 33-fold (1.52 log units) away from the limit.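

In this assay compound 3 gives a limit of the assay and not a number: the limit of > 10000 nM in this assay, at which 1 of the 3 values shown sits. Pyridin-3-yl in place of 1H-imidazol-4-yl on a saturated chain carbon bound to an aromatic carbon amounts to an at least 330-fold higher number from compound 2 to compound 3 (2.53 log units; beyond the scatter), which lies beyond the scatter. The earlier pair differed in core and could not isolate this position, whereas this single change on the shared core shows that the aromatic ring at this place can by itself move the read-out by a large step.

The change alters ring size and hydrogen-bond donor count together, so the data do not tell which of the two goes with the step. On these data alone, how a 1H-imidazol-1-yl group, a phenyl ring or a longer chain to the imidazole would read at this place remains open.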